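The source may hold more compounds than are shown below. What is called first, only, known or untested is meant among the compounds shown, and "the series" means these compounds.

In a functional assay on A549 cells (Homo sapiens) for antiproliferative activity, read by MTT assay, with a stated time of 72 h (on this read-out higher numbers stand for weaker inhibition and lower numbers for stronger inhibition), compound 1 `NC1=NC2(CCSCC2)N(OCCCOc2ccc(Br)cc2)C(N)=N1` gives 740 nM and compound 2 `NC1=NC2(CCOCC2)N(OCCCOc2cccc(Cl)c2Cl)C(N)=N1` gives 100 nM. Compound 2 therefore holds the lower of the two numbers, meaning the stronger inhibition, and the gap between them lies beyond the usual scatter of repeated measurements. These two compounds differ in more than one place, so their gap cannot be assigned to any single group.

Compound 3 `NC1=NC2(CCOCC2)N(OCCCOc2ccccc2Br)C(N)=N1` departs from compound 2 in one place: 2-bromophenyl in place of 2,3-dichlorophenyl on an oxygen on a saturated carbon. In words, 2-bromophenyl stands in place of 2,3-dichlorophenyl on an oxygen on a saturated carbon.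

Among the compounds with values here, no measured pair isolates a single change, so any expectation here remains loose. Within the data shown here, compound 2, at 100 nM, is the better of only two numbers, so a move toward weaker inhibition seems likelier than a further gain, though a result within the scatter would be no surprise. The expected change is modest: a 2.2-fold higher number from compound 2 to compound 3 (0.34 log units; beyond the scatter). For compound 3, the estimated value is 220 nM, with an expected range of 70 nM to 700 nM.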

Compound 3, half-maximal inhibitory concentration: 160 nM
Beside the measured number, compound 3's estimate is 1.4-fold (0.14 log units) above it; the range from low to high includes it.
By their numbers in this assay, from the lowest: compounds 2 and 3 (each within the scatter of the next); then compound 1.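

In this assay, within the data shown here, the change reads as a 1.6-fold higher number from compound 2 to compound 3 (0.20 log units; within the scatter), so this is the first comparison in which only the aromatic group differs. At this place, on an oxygen on a saturated carbon, 2-bromophenyl and 2,3-dichlorophenyl cannot be told apart by this read-out, even though the two groups carry different halogens in different numbers. Within these two compounds, then, the activity does not depend on keeping the 2,3-dichlorophenyl group, although nothing available explains this closeness.

From the compounds shown here alone, whether any halogen is needed stays open, as does how far this tolerance extends: a plain phenyl with no halogen, a pyridine ring or a methoxy-bearing phenyl at this place would test it, and a longer chain would probe the link to the oxygen. Compound 1 still differs from compound 2 and compound 3 in more than one place, so the separate contributions of its sulfur-containing ring and its 4-bromophenyl group remain unresolved.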